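This account rests on a few compounds, and the source may have more. Where it says the series, first, only, none or still open, it means among the compounds named here.

Compound 1 `CCCNC(=O)/N=C(\N)NCCCc1sc(N)nc1C` was tested in an assay on membranes from Sf9 cells for displacement of a labelled ligand from histamine H2 receptor (Homo sapiens), read by scintillation counting, with a stated time of 60 min (on this read-out lower numbers stand for stronger inhibition and higher numbers for weaker inhibition), where compound 1 gives 105 nM. Among the three measured compounds, compound 1 holds the second highest number. Its nearest neighbour is compound 3 `Cc1ccc(CC(C)CNC(=O)/N=C(\N)NCCCc2sc(N)nc2C)cc1`, which in this assay gives 72.4 nM; the step of a 1.5-fold lower number from compound 1 to compound 3 (0.16 log units; within the scatter) shows that adding a 4-methylbenzyl group on the saturated chain changed little. Furthest away is compound 2 `CCCCCCNC(=O)/N=C(\N)Nc1cccc(-c2csc(N)n2)c1`, which gives 692 nM in this assay; compound 2 differs from compound 1 in more than one place, so its weaker number cannot be tied to a single change.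

Compound 4 `Cc1nc(N)sc1CCCN/C(N)=N/C(=O)NC(C)c1ccco1` has not yet been measured. It differs from compound 1 by 1-(furan-2-yl)ethyl in place of propyl on an amide-type nitrogen. Among the compounds with values here, the only single step available, from compound 1 to compound 3, also altered the group carried by that amide-type nitrogen and stayed within the scatter. Within the data shown here, that step therefore suggests that changing what hangs from this nitrogen does not move the number much, although a ring entering directly on the carbon next to the nitrogen has no measured precedent here.

On this basis, compound 4 is expected to give about 90 nM in this assay, most likely between 35 nM and 230 nM. The expected step of a 1.2-fold lower number from compound 1 to compound 4 (0.07 log units; within the scatter) is estimated to lie within the scatter.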

Compound 4, inhibition constant: 31.6 nM
For compound 4 the middle estimate is 2.8-fold (0.45 log units) above the measured one; the whole stated range lies above it.
By their numbers in this assay, from the lowest: compound 4; then compounds 3 and 1 (each within the scatter of the next); then compound 2.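

In this assay the group on the amide-type nitrogen now proves able to move the number: a 3.3-fold lower number from compound 1 to compound 4 (0.52 log units; beyond the scatter) is a modest step, but it lies beyond the scatter, whereas a 1.5-fold lower number from compound 1 to compound 3 (0.16 log units; within the scatter) stayed within it. This position is therefore not indifferent to what it carries, and replacing propyl with 1-(furan-2-yl)ethyl, which brings in a five-membered aromatic ring with one hetero atom and one hydrogen-bond acceptor, goes with stronger inhibition. Nothing among the data shown explains this gain, so the part played by the ring, by its oxygen or by the rest of the new group remains unknown.

From the compounds shown here alone, what remains open is how far the furan ring itself matters, since a 1-phenylethyl or a 1-(thiophen-2-yl)ethyl group on the same nitrogen would test a different ring, and a furan-2-ylmethyl group would test a shorter link to it. A single favourable step also cannot show whether larger rings or a plain cyclohexyl group would give a similar number on the core of compound 1.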